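Swapping a Trifluoromethyl for a Methoxy on a Biphenyl Phenol

A few compounds are considered here, and "the series" means these few. Any claim that something is new, unique, unknown or untested is made for them only; others in the source may bear on it.

Measured compounds:
compound 1 `C=CCc1cc(-c2ccc(C(F)(F)F)cc2)ccc1O`: 74800 nM
compound 2 `C=CC(C)(C)c1cc(-c2cccc([N+](=O)[O-])c2)ccc1O`: 45100 nM
compound 3 `C=CCc1cc(-c2cc(F)cc(F)c2)ccc1O`: 78200 nM

Of the compounds shown here, three sharing the core of compound 1 have been tested in a functional assay on Lewis lung carcinoma cells (Mus musculus) for antiproliferative activity, read by MTT assay, with a stated time of 24 h; a lower number here means a stronger inhibitor, a higher number a weaker inhibitor. Compound 1 gives 74800 nM, the second highest of the three numbers. Compound 3 sits closest, with a number that differs from compound 1 by an amount within the scatter, and compound 2 gives a lower number that also stays within the scatter. The three values therefore show no difference that can be read as a real ranking.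

Compound 4 `C=CCc1cc(-c2ccc(OC)cc2)ccc1O` has not yet been measured. It differs from compound 1 in one place: methoxy in place of trifluoromethyl on an aromatic carbon. Going by the values given here, no measured pair shows the effect of this change, so no step is known for it. The expectation is that the step from compound 1 to compound 4 in this assay, a 1.1-fold higher number from compound 1 to compound 4 (0.03 log units; within the scatter), will be small, in either direction, and not clearly beyond the scatter. Compound 4 is estimated at 80000 nM, with a range from 30000 nM to 200000 nM.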

Compound 4, half-maximal inhibitory concentration: > 100000 nM
Compound 4: a limit, no number; the forecaster's own chance of this, stated with the estimate: 10%; middle value at least 1.2-fold (0.09 log units) away from the limit.
By their numbers in this assay, from the lowest: compounds 2, 1 and 3 (each within the scatter of the next). At a limit, above all of these: compound 4.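

Of the compounds shown, this pair is the only one that isolates a single change on the shared core: in this assay, methoxy in place of trifluoromethyl on this aromatic carbon, para to a large group, gives an at least 1.3-fold higher number from compound 1 to compound 4 (0.12 log units; that floor lies within the scatter). That step is only a floor, so the pair shows no sign that methoxy makes a stronger inhibitor, but it cannot establish a real loss either. As far as these compounds go, compound 4 is read only as a limit, not a number, and how far its true value lies past that limit stays unknown: the limit of > 100000 nM in this assay, at which 1 of the 4 values shown sits.

From the compounds shown here alone, the real size of this step remains open until compound 4 has a number rather than a limit. Going by these compounds, it also remains open whether an amine or a carboxylic acid on this aromatic carbon would give a lower number than trifluoromethyl.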